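The source may hold more compounds than are shown below. What is called first, only, known or untested is meant among the compounds shown, and "the series" means these compounds.

Measured so far:
Compound 1 `Cn1c(-c2ccccc2Cl)cnc1NC(=O)c1ncc[nH]1` reaches only the limit > 50000 nM in a toxicity assay on THP-1 cells (Homo sapiens) for inhibition; on this read-out higher numbers stand for lower toxicity in this test and lower numbers for higher toxicity in this test.
Compound 2 `Cn1c(-c2ccccc2Cl)cnc1NC(=O)c1ccc(F)cc1` likewise stops at the limit > 50000 nM in this assay.
Compound 3 `COc1ccc(-c2cnc(NC(=O)c3ccc(C)cc3)n2C)cc1` stops at the limit > 100000 nM in this assay.

Compound 2 stands at the limit described by the limit of > 50000 nM in this assay, at which 2 of the 3 values shown sit, so its true half-maximal cytotoxic concentration is not known, only that it lies beyond that point. The third value sits at the limit described by the limit of > 100000 nM in this assay, at which 1 of the 3 values shown sits, which is no more informative. For the measured compounds named here, the single step between measured compounds that differ in one place, a step that the two limits leave unreadable from compound 1 to compound 2, cannot be read in size, since both ends are limits. The account now turns to compound 4 `Cn1c(-c2ccccc2Br)cnc1NC(=O)c1ccc(F)cc1`, which differs from compound 2 by bromo in place of chloro on an aromatic carbon. Going by the values given here, no measured step bears on this change: the only step on hand, a step that the two limits leave unreadable from compound 1 to compound 2, concerns a different part of the molecule and has no readable size. With all three measured compounds at limits and no readable step, compound 4 is expected to show no shift beyond the scatter in this assay, so the expected step is a step that the limit leaves unreadable from compound 2 to compound 4. Compound 4 is therefore estimated at 60000 nM, within a range from 25000 nM to 150000 nM, most likely again reported only as a limit.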

Compound 4, half-maximal cytotoxic concentration: > 100000 nM
Compound 4 ended at the assay's limit (the forecaster's own chance of this, stated with the estimate: 80%); middle value at least 1.6-fold (0.22 log units) from the limit.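

No size can be read for the change from compound 2 to compound 4 in this assay: both ends are limits, not numbers. The compounds shown leave open where the true half-maximal cytotoxic concentration of any of them lies, and whether bromo in place of chloro on the aromatic carbon changes it at all.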